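A few compounds are considered here, and "the series" means these few. Any claim that something is new, unique, unknown or untested is made for them only; others in the source may bear on it.

Notes on the series. Compound 1 `O=C(O)Cc1sc(C(c2ccc(F)cc2)c2ccc(F)cc2)nc1-c1cc(F)cc(F)c1` in an in vitro assay on HEK385-7 cells for displacement of a labelled ligand from prostaglandin D2 receptor 2 (Homo sapiens) (a lower number here means a stronger inhibitor, a higher number a weaker inhibitor), gives 35 nM and stands at the low end of the three numbers shown. Compound 3 `O=C(O)Cc1sc(C(c2ccccc2)c2ccc(Cl)cc2)nc1-c1ccc(Cl)cc1` gives 45 nM, which lies within the scatter of compound 1. Among the compounds with values here, compound 2 `O=C(O)Cc1sc(C(c2ccc(F)cc2)c2ccc(F)cc2)nc1-c1ccnc(N2CCC2)c1` gives 660 nM; the step of a 19-fold higher number from compound 1 to compound 2 (1.28 log units; beyond the scatter) is the one change so far at the same place on the shared core.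

Compound 4 `O=C(O)Cc1sc(C(c2ccc(F)cc2)c2ccc(F)cc2)nc1-c1cc(F)nc(F)c1` is not yet measured. It differs from compound 1 as follows: 2,6-difluoropyridin-4-yl in place of 3,5-difluorophenyl on an aromatic carbon. Within the data shown here, the only step that bears on this is the one from compound 1 to compound 2, which swapped the same 3,5-difluorophenyl for a different pyridin-4-yl group and gave a large rise in the number. Compound 4 keeps both fluorines and adds only the ring nitrogen, so a smaller step in the same direction is expected, possibly none beyond the scatter. The estimate for compound 4 is 80 nM, with a range of 30 nM to 250 nM, which means an expected step of a 2.3-fold higher number from compound 1 to compound 4 (0.36 log units; beyond the scatter).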

Compound 4, half-maximal inhibitory concentration: 5.4 nM
Beside the measured number, compound 4's estimate is 15-fold (1.17 log units) above it, and the stated range ends above it.
By their numbers in this assay, from the lowest: compound 4; then compounds 1 and 3 (each within the scatter of the next); then compound 2.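

In this assay, 2,6-difluoropyridin-4-yl in place of 3,5-difluorophenyl, on the aromatic carbon next to the ring nitrogen, gives a 6.5-fold lower number from compound 1 to compound 4 (0.81 log units; beyond the scatter), so a ring nitrogen at this place does not by itself raise the number. Between the two pyridin-4-yl groups the step is a 120-fold lower number from compound 2 to compound 4 (2.09 log units; beyond the scatter), which shows that the rise seen earlier with 2-(azetidin-1-yl)pyridin-4-yl cannot be laid on the pyridine ring alone and that the groups carried on that ring matter strongly here. Nothing available accounts for either step.

The compounds shown leave open whether a pyridin-4-yl group with a single fluorine, or with chlorine or methoxy in place of the fluorines, would keep this low number. They also leave open whether the same swap would give a similar step on the other large group of compound 3.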